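Allyl Gives Way to (2-Carboxyethyl)carbonyl on an Aromatic Oxygen

The compounds below may be only part of what the source reports. "The series", "measured", "known", "first", "only" and "open" are said of these compounds alone.

Measured so far:
- compound 1, `C=CCOc1c(C)c(C)c2c(c1C)CCC(C)(COc1ccc(/C=C3\SC(=O)NC3=O)cc1)O2`: 45%
- compound 2, `C=CCOc1c(C)c(C)c2c(c1C)CCC(C)(COc1ccc(/C=C3\SC(=O)NC3=O)cc1OCC)O2`: 107%

Of the compounds shown here, two have been tested in a functional assay on MCF7 cells (Homo sapiens), tested at 2.5 uM; on this read-out lower numbers stand for a stronger effect and higher numbers for a weaker effect at the one concentration tested. Compound 1 gives the lowest of the two numbers; its nearest neighbour is compound 2, and the step of a number 62 percentage points higher from compound 1 to compound 2 (beyond the scatter) is large and lies beyond the scatter. That step, however, concerns an ethoxy in place of hydrogen on an aromatic carbon and has nothing in common with the change now at hand.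

Compound 3, `Cc1c(C)c2c(c(C)c1OC(=O)CCC(=O)O)CCC(C)(COc1ccc(/C=C3\SC(=O)NC3=O)cc1)O2`, differs from compound 1 in a single place: (2-carboxyethyl)carbonyl in place of allyl on an oxygen on an aromatic ring. Among the compounds with values here, no measured pair shows what this exchange does, so the expectation can rest only on compound 1 itself. Compound 3 is therefore estimated at 60%, with a range from 25% to 100%, which means an expected step of a number 15 percentage points higher from compound 1 to compound 3 (beyond the scatter), wide enough to allow either direction.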

Compound 3, a percentage reported as activity, at one concentration (the size of the read-out at that concentration, not a potency): 115%
Beside the measured number, compound 3's estimate is 55 percentage points below it; the whole stated range lies below it.
By their numbers in this assay, from the lowest: compound 1; then compounds 2 and 3 (each within the scatter of the next).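

Exchanging allyl for (2-carboxyethyl)carbonyl on an oxygen on an aromatic ring gives, in this assay, a number 70 percentage points higher from compound 1 to compound 3 (beyond the scatter), so this oxygen is not a place where substitution passes unnoticed. The earlier pair spoke only of an ethoxy on an aromatic carbon, where the step is a number 62 percentage points higher from compound 1 to compound 2 (beyond the scatter); now a second place in compound 1 also gives a weaker effect at the one concentration tested when changed. Nothing in the available data accounts for the size of the new step.

As far as these compounds go, it remains open whether the weaker effect follows the carboxylic acid at the end of the chain or the carbonyl on the oxygen. An acetyl group or the methyl ester of the same chain would separate the two, and a methyl or propyl group would show how far the allyl group itself matters.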